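Adding a pyrazolyl group back onto the aromatic amine

The source may hold more compounds than are shown below. What is called first, only, known or untested is meant among the compounds shown, and "the series" means these compounds.

Measured so far:
Compound 1, `Cc1c(Nc2nc(N)c3c(C#N)c(N4CCC[C@H]4C)n(C)c3n2)cnn1C` — 75 nM in an assay on isolated protein for inhibition of Leucine-rich repeat serine/threonine-protein kinase 2 (Homo sapiens), read by TR-FRET and LanthaScreen, with stated times of 50 min and 30 min, in the presence of a further agent that is not named here; on this read-out lower numbers stand for stronger inhibition and higher numbers for weaker inhibition
Compound 2, `C[C@@H]1CCCN1c1c(C#N)c2c(N)nc(N)nc2n1C` — 248 nM in this assay

Compound 2 carries the free amine on the shared core. Within the data shown here, it stands as the higher of the two numbers in this assay; the only other value, that of compound 1, lies lower, the step being a 3.3-fold higher number from compound 1 to compound 2 (0.52 log units; beyond the scatter). Compound 3, `Cc1n[nH]cc1Nc1nc(N)c2c(C#N)c(N3CCC[C@H]3C)n(C)c2n1`, has not yet been measured. It differs from compound 2 in one place: 3-methyl-1H-pyrazol-4-yl in place of hydrogen on a nitrogen on an aromatic ring.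

Among the measured compounds shown here, the one measured step that bears on this change is the one from compound 1 to compound 2, which removed a closely related group, the 1,5-dimethyl-1H-pyrazol-4-yl, from the same nitrogen and gave a 3.3-fold higher number from compound 1 to compound 2 (0.52 log units; beyond the scatter). The change from compound 2 to compound 3 runs the other way, installing a pyrazolyl that differs from that of compound 1 only in the number and placement of methyl groups on the ring. A step of about the same size, but in the lowering direction, is therefore expected in this assay; the estimated step is a 3.1-fold lower number from compound 2 to compound 3 (0.49 log units; beyond the scatter). For compound 3 the expected value in this assay is 80 nM, with a likely range of 30 nM to 220 nM.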

Compound 3, half-maximal inhibitory concentration: 42 nM
Estimate against measurement, compound 3: 1.9-fold (0.28 log units) above; the range from low to high includes it.
By their numbers in this assay, from the lowest: compounds 3 and 1 (each within the scatter of the next); then compound 2.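

In this assay, a second pyrazolyl group on this nitrogen also gives a step beyond the scatter, a 5.9-fold lower number from compound 2 to compound 3 (0.77 log units; beyond the scatter), so the effect of replacing the hydrogen is not confined to the 1,5-dimethyl-1H-pyrazol-4-yl of compound 1. The direct exchange of that group for 3-methyl-1H-pyrazol-4-yl gives a 1.8-fold lower number from compound 1 to compound 3 (0.25 log units; within the scatter), so this assay does not separate the two groups, even though they differ in the number and placement of their methyl groups and only the 3-methyl-1H-pyrazol-4-yl keeps a hydrogen on a ring nitrogen. Nothing available here accounts for why either pyrazolyl group lowers the number relative to the free amine.

Going by these compounds, it remains open whether the step needs a pyrazolyl ring at all, or whether a phenyl ring or a simple methyl on the same nitrogen would give a similar number. On these data alone, all three compounds also share the rest of the core, so it is equally open whether the step would hold with a different group elsewhere on it.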